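This account rests on a few compounds, and the source may have more. Where it says the series, first, only, none or still open, it means among the compounds named here.

Working notes on the series. Going by the values given here, compound 3 `CCNC(=O)Nc1cccc(S(=O)(=O)Nc2ccccc2C)c1` gives 102000 nM in a functional assay on HT-29 cells (Homo sapiens) for cytotoxicity, read by sulforhodamine B assay, with a stated time of 48 h (on this read-out higher numbers stand for weaker inhibition and lower numbers for stronger inhibition), the highest of the three numbers measured so far. Compound 1 `Cc1ccccc1NS(=O)(=O)c1cccc(NC(=O)NCCCCl)c1` gives 42000 nM, and compound 2 `CCNC(=O)Nc1ccc(S(=O)(=O)Oc2ccccc2CC)cc1` gives 12000 nM. Among the compounds with values here, the only single-point step measured, a 2.4-fold higher number from compound 1 to compound 3 (0.39 log units; beyond the scatter), concerns the urea end of the molecule and does not touch the site now in question. Compound 4 `CCCc1ccccc1NS(=O)(=O)c1cccc(NC(=O)NCC)c1` carries ethyl in place of hydrogen on a saturated chain carbon bound to an aromatic carbon; the same difference, cut one bond further out, reads methyl to propyl. Within the data shown here, no measured pair changes this position alone, so the step is uncalibrated; compound 2 differs from compound 3 in more than one place and cannot anchor it. The expectation for compound 4 is therefore a step of a 1.3-fold lower number from compound 3 to compound 4 (0.11 log units; within the scatter), within the scatter. Compound 4 is estimated at 80000 nM, range 30000 nM to 250000 nM.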

Compound 4, half-maximal inhibitory concentration: 41000 nM
Compound 4: middle estimate off by 2.0-fold (0.29 log units), on the high side; the measured number falls inside the stated range.
By their numbers in this assay, from the lowest: compound 2; then compounds 4 and 1 (each within the scatter of the next); then compound 3.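

This position now has its first calibrated step: ethyl in place of hydrogen on a saturated chain carbon bound to an aromatic carbon gives a 2.5-fold lower number from compound 3 to compound 4 (0.40 log units; beyond the scatter). The change therefore moves the cytotoxicity read-out beyond the scatter, with a modest step toward stronger inhibition, and the position is not silent to added chain length. No available evidence accounts for this step. As far as these compounds go, whether a longer chain such as hexyl continues the direction remains open. So does the effect of an amine or a carboxylic acid on this carbon.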